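Thiophene for fluorophenyl on the shared core

This account rests on a few compounds, and the source may have more. Where it says the series, first, only, none or still open, it means among the compounds named here.

Compound 1 `N#Cc1c(-c2ccc(F)cc2)nc2c(c(-c3ccccc3)nn2-c2ccccc2)c1-c1ccc(O)cc1` is the measured anchor of this pair. Going by the values given here, in a functional assay on MV4-11 cells (Homo sapiens) for antiproliferative activity, read by resazurin assay, with a stated time of 72 h (a higher number here means a weaker inhibitor, a lower number a stronger inhibitor), compound 1 gives 11600 nM, the only full number among the two values shown. Compound 2 `COc1ccc(-c2c(C#N)c(-c3ccccc3)nc3c2c(-c2ccccc2)nn3-c2ccccc2)cc1OC` carries a dimethoxyphenyl group and a plain phenyl group where compound 1 carries the 4-hydroxyphenyl and 4-fluorophenyl groups. In this assay compound 2 reaches only a limit and no number, > 25000 nM. Hence (the limit of > 25000 nM in this assay, at which 1 of the 2 values shown sits), and no step between two compounds differing in one place can be read from the set.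

Compound 3 `N#Cc1c(-c2cccs2)nc2c(c(-c3ccccc3)nn2-c2ccccc2)c1-c1ccc(O)cc1` differs from compound 1 in one place: thiophen-2-yl in place of 4-fluorophenyl on an aromatic carbon, on an aromatic carbon next to the ring nitrogen, ortho to a cyano group and meta to a 4-hydroxyphenyl group. Among the compounds with values here, no measured step of this kind exists here, so size and direction in this assay cannot be taken from data; the expected step is none beyond the usual scatter. Compound 3 is expected to give 12000 nM, between 5000 nM and 28000 nM, an estimated step of a 1.0-fold higher number from compound 1 to compound 3 (0.01 log units; within the scatter).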

Compound 3, half-maximal inhibitory concentration: 34200 nM
Compound 3: the middle estimate sits 2.9-fold (0.45 log units) below what was measured; measured number outside the range, above it.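

Going by these compounds alone, with the 4-hydroxyphenyl group and the rest of the shared core held constant, thiophen-2-yl in place of 4-fluorophenyl on the aromatic carbon next to the ring nitrogen gives, in this assay, a 2.9-fold higher number from compound 1 to compound 3 (0.47 log units; beyond the scatter), the first step that isolates one place. This position, ortho to a cyano group, therefore does not accept these two aromatic rings alike: in this pair, the five-membered ring with sulfur gives the weaker inhibitor. No measurement shown bears on the reason for this step.

This single step does not separate the loss of the fluorine from the change of ring, and other steps at this position cannot be read, since compound 2 differs from compound 1 in more than one place. Going by these compounds, whether a morpholine or a carboxylic acid on this carbon would give a lower number than compound 1, at 11600 nM, remains open.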